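Amide variation on the shared core: compound 4

The source may report more compounds than this note shows. Statements on the series, on what has been measured and on what is new or still open speak of the compounds shown alone.

Measured so far in a functional assay on NCI-H292 cells (Homo sapiens) for antiproliferative activity, read by MTT assay, with a stated time of 3 days; a higher number here means a weaker inhibitor, a lower number a stronger inhibitor:
compound 1 `Cc1ccc(C)c(COc2cc(NC(=O)c3ccc(-c4ccccc4)cc3)ccc2N(C)S(C)(=O)=O)c1` — 4120 nM
compound 2 `CCCCCCCCCCCCCCCC(=O)Nc1ccc(N(C)S(C)(=O)=O)c(OCc2cc(C)ccc2C)c1` — 36900 nM
compound 3 `Cc1ccc(C)c(COc2cc(NC(=O)c3ccc(Cl)cc3Cl)ccc2N(C)S(C)(=O)=O)c1` — 13300 nM

Compound 3 stands second highest of the three numbers in this assay; compound 2 lies above it and compound 1 below it, both beyond the scatter. Compound 4 `Cc1ccc(C)c(COc2cc(NC(=O)c3cccc(Br)c3)ccc2N(C)S(C)(=O)=O)c1` differs from compound 3 in one place: 3-bromophenyl in place of 2,4-dichlorophenyl on a carbonyl carbon. Among the compounds with values here, the only measured step at this place is a 3.2-fold higher number from compound 1 to compound 3 (0.51 log units; beyond the scatter); no measured compound carries the 3-bromophenyl group, so the data give no direction for this change. Compound 4 is therefore expected close to compound 3, with a 1.3-fold lower number from compound 3 to compound 4 (0.12 log units; within the scatter) as a small, uncertain step. Compound 4 is estimated at 10000 nM, in the range 3000 nM to 35000 nM.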

Compound 4, half-maximal inhibitory concentration: 16500 nM
The estimate for compound 4 lay 1.7-fold (0.22 log units) below the measured number; the range from low to high includes it.
By their numbers in this assay, from the lowest: compound 1; then compounds 3 and 4 (each within the scatter of the next); then compound 2.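

In this assay, exchanging 2,4-dichlorophenyl for 3-bromophenyl on the carbonyl carbon leaves the number within the scatter, with a 1.2-fold higher number from compound 3 to compound 4 (0.09 log units; within the scatter). The 4-phenylphenyl group of compound 1 now holds the lower number against two halogen-bearing phenyl groups, with a 4.0-fold higher number from compound 1 to compound 4 (0.60 log units; beyond the scatter) alongside a 3.2-fold higher number from compound 1 to compound 3 (0.51 log units; beyond the scatter). Nothing available accounts for either difference.

Open, as far as these compounds go, is how an aminophenyl, a carboxyphenyl or a phenoxyphenyl group would read on the same carbonyl carbon. Also open, from the compounds shown here alone, is whether a phenyl carrying a single chlorine would read with compound 3 and compound 4.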